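This account rests on a few compounds, and the source may have more. Where it says the series, first, only, none or still open, it means among the compounds named here.

In a functional assay on HepG2 cells (Homo sapiens) for antiproliferative activity, read by MTT assay, with a stated time of 48 h (on this read-out higher numbers stand for weaker inhibition and lower numbers for stronger inhibition), three compounds built on a shared core have been measured. Compound 1 `COc1ccc(-c2c(Nc3ccc(C)cc3)c3ccc(OC)cc3oc2=O)cc1` gives 74400 nM. Compound 2 `COc1ccc(-c2c(Nc3ccc(F)cc3)c3ccc(O)cc3oc2=O)cc1` gives 65600 nM, within the scatter of compound 1. Compound 3 `COc1ccc(-c2c(Nc3ccc(C)c(O)c3)c3ccc(O)cc3oc2=O)cc1` has only a limit, > 75300 nM, so it has no exact position among the numbers shown.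

Compound 4 `COc1ccc(-c2c(Nc3ccc(C)cc3)c3ccc(O)cc3oc2=O)cc1` has not been measured. It differs from compound 3 by hydrogen in place of hydroxy on an aromatic carbon, ortho to a methyl group: hydrogen in place of hydroxy on an aromatic carbon. In other words, 3-hydroxy-4-methylphenyl becomes 4-methylphenyl.

One measured step involves this group, an at least 1.1-fold higher number from compound 2 to compound 3 (0.05 log units; that floor lies within the scatter). It gives only a floor, so it shows no clear effect. Compound 1 also carries 4-methylphenyl and gives 74400 nM, which suggests that compound 4 should stay in the same weak range. In this assay, going by the values given here, no step clearly beyond the scatter is therefore expected, though a slightly lower number is possible. The expected change is an at least 1.1-fold lower number from compound 3 to compound 4 (0.06 log units; that floor lies within the scatter). Compound 4 is estimated at 65000 nM, with an expected range of 35000 nM to 110000 nM.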

Compound 4, half-maximal inhibitory concentration: 88300 nM
Beside the measured number, compound 4's estimate is 1.4-fold (0.13 log units) below it; measured number inside the range.
By their numbers in this assay, from the lowest: compounds 2, 1 and 4 (each within the scatter of the next).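

Compound 3 has only a limit, so the step that replaces its hydroxy with hydrogen to give compound 4 cannot be read: the limit of > 75300 nM in this assay, at which 1 of the 4 values shown sits. In this assay, the 4-methylphenyl group now has an exact number alongside a hydroxy on the shared core, and methyl in place of fluoro gives a 1.3-fold higher number from compound 2 to compound 4 (0.13 log units; within the scatter), which lies within the scatter. Hydrogen in place of methyl on the oxygen gives a 1.2-fold higher number from compound 1 to compound 4 (0.07 log units; within the scatter), also within the scatter, so neither change separates these compounds.

Going by these compounds, whether the hydroxy of the 3-hydroxy-4-methylphenyl group changes the number at all remains open. Also open, on these data alone, is whether an amine or a carboxylic acid in place of that hydroxy would move the number clearly beyond the scatter.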